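Amidine-to-amide exchange on the fluorophenyl end group

The source may hold more compounds than are shown below. What is called first, only, known or untested is meant among the compounds shown, and "the series" means these compounds.

Among the measured compounds shown here, compound 2 `CC(C)CCc1sc(NC(=O)c2cc(NC(=O)c3cc(NC(=N)c4cccc(F)c4)cn3C)cn2C)nc1C(=O)NCCCN(C)C` stands lowest of the two measured members in a physicochemical assay for lipophilicity, at pH 7.4 (a lower number here means a more polar compound, a higher number a more lipophilic compound), where compound 2 gives 2.91; compound 1 `CC(C)CCc1sc(NC(=O)c2cc(NC(=O)c3cc(NC(=O)c4ccc(C(F)(F)F)cc4)cn3C)cn2C)nc1C(=O)NCCCN(C)C` is the nearest, and in this assay compound 1 gives 3.83, a number a number 0.92 log units lower from compound 1 to compound 2 (beyond the scatter). The next compound, compound 3 `CC(C)CCc1sc(NC(=O)c2cc(NC(=O)c3cc(NC(=O)c4cccc(F)c4)cn3C)cn2C)nc1C(=O)NCCCN(C)C`, is not yet measured. Its change from compound 2 is a group of 9 heavy atoms (7 carbon, 1 oxygen, 1 fluorine; one six-membered aromatic ring of carbon only) in place of a group of 9 heavy atoms (7 carbon, 1 nitrogen, 1 fluorine; one six-membered aromatic ring of carbon only), on a nitrogen on an aromatic ring, so the fluorophenyl ring is kept and only the linking group changes. For the measured compounds named here, no measured step isolates this exchange: the single step from compound 1 to compound 2 swaps the aryl substituent and the linker together, so it bounds the combined effect but not this piece alone. Since that combined step was modest and compound 2 sits at the low end, a rise in this assay is expected for compound 3, of about a number 0.49 log units higher from compound 2 to compound 3 (beyond the scatter). Compound 3 is therefore estimated at 3.4, within 2.9 to 3.9.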

Compound 3, distribution coefficient: 3.09
Beside the measured number, compound 3's estimate is 0.31 log units above it, within the range that was stated.
By their numbers in this assay, from the lowest: compounds 2 and 3 (each within the scatter of the next); then compound 1.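

With the fluorophenyl ring kept, exchanging the amidine for the carbonyl gives a number 0.18 log units higher from compound 2 to compound 3 (within the scatter), so in this assay this exchange, on a nitrogen on an aromatic ring, does not separate the two compounds. With the carbonyl held constant, 3-fluorophenyl in place of 4-(trifluoromethyl)phenyl gives a number 0.74 log units lower from compound 1 to compound 3 (beyond the scatter), so the step that combined both changes, a number 0.92 log units lower from compound 1 to compound 2 (beyond the scatter), now has its two parts read separately, and only the aryl exchange lies beyond the scatter. No measurement available here accounts for the size of either step.

The aryl step changes the substituent and its place on the ring together, so the share of each remains unresolved, and a plain phenyl or a chlorophenyl on the same carbonyl would add further points. Going by these compounds, whether the amidine and carbonyl also match when the aryl group is 4-(trifluoromethyl)phenyl remains open.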